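This account rests on a few compounds, and the source may have more. Where it says the series, first, only, none or still open, it means among the compounds named here.

Of the compounds shown here, three have been read so far in a physicochemical assay for solubility, measured as kinetic solubility; a lower number here means a less soluble compound, a higher number a more soluble compound. For compound 1 `CC(=O)Nc1c(F)cc(C(=O)N[C@H]2CC[C@H](O)CC2)cc1O[C@@H](C)c1ccccc1` the result is >= 159 ug/mL, which is a limit of the assay and not a number. For compound 2 `CNC(=O)c1cc(C(=O)N[C@H]2CC[C@H](O)CC2)c([C@@H](C)c2cccc(F)c2)o1` the result is >= 63 ug/mL, which is likewise a limit and not a number. Among the measured compounds shown here, compound 3 `CC[C@@H](c1ccccc1)n1nc(C(=O)NC)cc1C(=O)N[C@H]1CC[C@H](O)CC1` is the only one with a true number, 138 ug/mL. Compound 2 therefore stands without a firm value, and the one further limit offers no firm comparison for it.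

Compound 4 `CNC(=O)c1cc(C(=O)N[C@H]2CC[C@H](O)CC2)c([C@@H](C)c2ccc(C)cc2)o1` keeps the rest of compound 2 and has 4-methylphenyl in place of 3-fluorophenyl on a saturated chain carbon bound to an aromatic carbon and a saturated chain carbon. For the measured compounds named here, no measured pair shows this change. No step beyond the usual scatter is expected in this assay, and no direction is favoured. The estimated step is a step that the limit leaves unreadable from compound 2 to compound 4. Compound 4 is expected at about 70 ug/mL, with an estimated range of 30 ug/mL to 150 ug/mL.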

Compound 4, solubility: >= 245 ug/mL
Compound 4 gave a limit, no number (the forecaster's own chance of this, stated with the estimate: 40%); middle value at least 3.5-fold (0.54 log units) from the limit.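

Compound 2 and compound 4 both stand as limits in this assay, so no step can be read for 4-methylphenyl in place of 3-fluorophenyl. The compounds shown leave open the true values of both compounds and whether this change shifts the read-out at all.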